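Swapping an aminophenyl for a formylphenyl on a weak inhibitor

The source may hold more compounds than are shown below. What is called first, only, known or untested is meant among the compounds shown, and "the series" means these compounds.

Measured so far:
compound 1 `c1ccc(COc2ccc(OCCOCCNc3ccncc3)cc2)cc1`: 20600 nM
compound 2 `Nc1ccccc1COc1ccc(OCCOCCNC2CCCC2)cc1`: 14000 nM

In a functional assay on SK-OV-3 cells (Homo sapiens) for inhibition, read by CCK-8 assay, with a stated time of 70 h (a lower number here means a stronger inhibitor, a higher number a weaker inhibitor), compound 2 gives 14000 nM, and compound 1 gives 20600 nM; the gap between them lies within the scatter, so neither can be called the stronger. Compound 3 `O=Cc1ccc(COc2ccc(OCCOCCNC3CCCC3)cc2)cc1` is not yet measured. It differs from compound 2 in one place: 4-formylphenyl in place of 2-aminophenyl on a saturated chain carbon bound to an oxygen on an aromatic ring. For the measured compounds named here, no step between measured compounds is known, so the change from compound 2 to compound 3 has no precedent here. With compound 2 at 14000 nM, compound 3 is expected to stay close, a step of a 1.1-fold higher number from compound 2 to compound 3 (0.03 log units; within the scatter) in this assay, no larger than the scatter. The estimate for compound 3 is 15000 nM, ranging from 5000 nM to 45000 nM.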

Compound 3, half-maximal inhibitory concentration: 45000 nM
The estimate for compound 3 lay 3.0-fold (0.48 log units) below the measured number, and the stated range covers the measured number.
By their numbers in this assay, from the lowest: compounds 2 and 1 (each within the scatter of the next); then compound 3.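

In this assay, for the compounds shown here, the group on the saturated chain carbon bound to an oxygen on an aromatic ring proves to matter: the change gives a 3.2-fold higher number from compound 2 to compound 3 (0.51 log units; beyond the scatter) and is the first step here to pass the scatter. The change alters both the group, amino to formyl, and its ring number, 2 to 4, so the step cannot be credited to either alone. Nothing measured here explains the step.

Open, going by these compounds, is how 4-aminophenyl or 2-formylphenyl would compare, since either would separate those two changes. Also open, on these data alone, is how a carboxylic acid at this ring position would compare.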